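A few compounds are considered here, and "the series" means these few. Any claim that something is new, unique, unknown or untested is made for them only; others in the source may bear on it.

Compound 1 `COC(=O)[C@H](CO)NC(=O)c1cnc2ccccc2c1Cl` defines the shared core of this series. In an ADME assay on CCRF-CEM cells (Homo sapiens) for cytotoxicity (a lower number here means that less compound is tolerated, a higher number that more compound is tolerated), compound 1 gives > 100 uM, which is a limit of the assay and not a number. Compound 3 `COC(=O)[C@H](CO)NC(=O)c1cnc2c(Cl)cccc2c1Cl` also gives > 100 uM in this assay, again a limit. Going by the values given here, compound 2 `COC(=O)[C@H](CO)NC(=O)c1cnc2cc(C)ccc2c1Cl` is the only member with a number, giving 59.6 uM in this assay. The step of an at least 1.6-fold lower number from compound 1 to compound 2 (0.22 log units; that floor lies within the scatter) comes with methyl in place of hydrogen on an aromatic carbon; the step that the two limits leave unreadable from compound 1 to compound 3 comes with chloro in place of hydrogen on an aromatic carbon, and its size cannot be read because the limit of > 100 uM in this assay, at which 2 of the 3 values shown sit, holds both of its ends. Compound 4 `COC(=O)[C@H](CO)NC(=O)c1cnc2cc(Cl)ccc2c1Cl` differs from compound 2 by chloro in place of methyl on an aromatic carbon. Both measured steps bear on this change, one with its floor inside the scatter and one unreadable, so no step beyond the scatter is expected in this assay, though a drift back toward the limit remains possible. Compound 4 is therefore expected to give 85 uM, within a range from 30 uM to 250 uM. The expected step of a 1.4-fold higher number from compound 2 to compound 4 (0.15 log units; within the scatter) is accordingly modest.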

Compound 4, half-maximal toxic concentration: > 100 uM
Compound 4: no number, only a limit (the forecaster's own chance of this, stated with the estimate: 50%); middle value at least 1.1-fold (0.07 log units) away from the limit.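

In this assay compound 4 gives > 100 uM, which is a limit of the assay and not a number. Chloro in place of methyl on this aromatic carbon comes with an at least 1.6-fold higher number from compound 2 to compound 4 (0.22 log units; that floor lies within the scatter), so a real difference between these two groups is possible but not established, and methyl remains the only group at this place that gives a number. The step between compound 1 and compound 4 cannot be read because both of its ends stand at the same limit: the limit of > 100 uM in this assay, at which 3 of the 4 values shown sit.

The compounds shown leave open how far beyond the limit hydrogen and chloro at this place really lie. They also leave open whether a longer chain such as ethyl, or a methoxy group or an amine, on this same carbon would give a number in this assay.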